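From Phenyl to 4-Hydroxyphenyl in Compound 3

The compounds below may be only part of what the source reports. "The series", "measured", "known", "first", "only" and "open" are said of these compounds alone.

Among the measured compounds shown here, in a functional assay on COLO 205 cells (Homo sapiens) for inhibition, read by sulforhodamine B assay, with a stated time of 48 h (on this read-out higher numbers stand for weaker inhibition of growth and lower numbers for stronger inhibition of growth), compound 1 (`O=C(Cc1csc2nc(-c3ccc(Br)cc3)cn12)N/N=C/c1ccccc1`) gives 66100 nM and stands highest of the two numbers so far. Compound 2 (`O=C(Cc1csc2nc(-c3ccc(Br)cc3)cn12)N/N=C/c1ccccc1O`) gives 5130 nM and carries a hydroxy group on its phenyl ring. For the measured compounds named here, that swap, hydroxy in place of hydrogen on an aromatic carbon, makes a 13-fold lower number from compound 1 to compound 2 (1.11 log units; beyond the scatter) and is the only measured step that bears on compound 3 (`O=C(Cc1csc2nc(-c3ccc(Br)cc3)cn12)N/N=C/c1ccc(O)cc1`). Compound 3 has the same kind of swap at another place (hydroxy in place of hydrogen on an aromatic carbon). One step cannot show how much the place matters, so a smaller step in the same direction is expected (a 4.1-fold lower number from compound 1 to compound 3 (0.62 log units; beyond the scatter)). For compound 3 the estimated value is 16000 nM with 4000 nM to 60000 nM as its expected range.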

Compound 3, concentration for 50% growth inhibition: 43700 nM
Compound 3: middle estimate off by 2.7-fold (0.44 log units), on the low side; the range from low to high includes it.
By their numbers in this assay, from the lowest: compound 2; then compounds 3 and 1 (each within the scatter of the next).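

Placed para to a large group, the hydroxy swap gives a 1.5-fold lower number from compound 1 to compound 3 (0.18 log units; within the scatter) in this assay, so the clear drop seen with compound 2 does not carry over to this place. Moving the group, with 4-hydroxyphenyl in place of 2-hydroxyphenyl, gives an 8.5-fold higher number from compound 2 to compound 3 (0.93 log units; beyond the scatter), which shows that where the hydroxy sits on the ring matters, not only that it is present.

As far as these compounds go, whether a methoxy group or an amine would follow compound 2 or compound 3 at these places stays open. Nothing measured here explains the difference between the two places.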